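Pyrazolopyrimidine chalcone series: antiproliferative read-out, next compound

The source may report more compounds than this note shows. Statements on the series, on what has been measured and on what is new or still open speak of the compounds shown alone.

Measured so far:
compound 1 `COc1ccc(C(=O)/C=C/c2cc(-c3cc(OC)c(OC)c(OC)c3)n3nc(-c4ccccc4)cc3n2)cc1OC`: 18300 nM
compound 2 `COc1cc(-c2cc(/C=C/C(=O)c3ccc(C)c(C)c3)nc3cc(-c4ccccc4)nn23)cc(OC)c1OC`: 13500 nM

Both compounds share one core and differ only in the aryl ring on the carbonyl carbon. In a functional assay on MDA-MB-231 cells (Homo sapiens) for antiproliferative activity, read by MTT assay, with a stated time of 24 h (on this read-out higher numbers stand for weaker inhibition and lower numbers for stronger inhibition), compound 1 gives 18300 nM and compound 2 gives 13500 nM. The single step recorded, a 1.4-fold lower number from compound 1 to compound 2 (0.13 log units; within the scatter), is within the scatter, so on the numbers shown compound 2 has the lowest value of the two, but the gap to compound 1 is not a real difference.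

Compound 3 `COc1cc(-c2cc(C(=O)/C=C/c3ccc(Cl)cc3)nc3cc(-c4ccccc4)nn23)cc(OC)c1OC` is not yet measured. Its change from compound 2 is (2-(4-chlorophenyl)ethenyl)carbonyl in place of 2-((3,4-dimethylphenyl)carbonyl)ethenyl on an aromatic carbon. This is both a swap of the aryl ring and a reversal of the enone, with the carbonyl now on the core side. For the measured compounds named here, only the step from compound 1 to compound 2 bears on it, and only for the aryl swap part; it was within the scatter. Going by the values given here, no measured pair informs the reversal. The expectation is therefore a step of no more than the scatter in this assay, direction uncertain, a 1.2-fold lower number from compound 2 to compound 3 (0.09 log units; within the scatter). Compound 3 is estimated at 11000 nM, with a range from 3500 nM to 35000 nM.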

Compound 3, half-maximal inhibitory concentration: 21600 nM
Compound 3: middle estimate off by 2.0-fold (0.29 log units), on the low side; measured number inside the range.
By their numbers in this assay, from the lowest: compounds 2, 1 and 3 (each within the scatter of the next).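

In this assay, the change at this position gives a 1.6-fold higher number from compound 2 to compound 3 (0.20 log units; within the scatter), so the reversed enone, with its carbonyl now on the aromatic carbon of the core, still gives a number that cannot be told apart from that of compound 2. The step combines two changes, the reversal of the enone and the replacement of the 3,4-dimethylphenyl ring by a 4-chlorophenyl ring, and the single result cannot divide it between them or show that either change alone is without effect. No measurement is available that would explain the result.

The compounds shown leave open how the reversed enone behaves with the 3,4-dimethylphenyl ring kept in place, which would separate the two changes, and whether the ethenyl link itself matters, as a saturated ethylene chain or an amide in its place would test. They also leave open whether a group of a different kind on the aryl ring, such as a morpholine amine or a carboxylic acid, would move the number in this assay beyond the scatter.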